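Cytotoxicity notes: adding methoxy to compound 3

This account rests on a few compounds, and the source may have more. Where it says the series, first, only, none or still open, it means among the compounds named here.

Among the compounds with values here, in an ADME assay on MT4 cells (Homo sapiens) for cytotoxicity, read by MTT assay (on this read-out higher numbers stand for lower toxicity in this test and lower numbers for higher toxicity in this test), compound 3 (`CCc1c(Cc2c(F)cccc2F)nc(SCC(=O)c2ccccc2)[nH]c1=O`) gives 56000 nM as the only actual number so far. Compound 1 (`CCc1c(Cc2c(F)cccc2Cl)nc(SCC(=O)c2ccc(OC)cc2)[nH]c1=O`) stands at > 11000 nM as a limit. Compound 2 (`COc1ccc(C(=O)CSc2nc(Cc3c(F)cccc3F)c(C)c(=O)[nH]2)cc1`) stands at > 60000 nM as a limit too. Compound 4 (`CCc1c(Cc2c(F)cccc2F)nc(SCC(=O)c2ccc(OC)cc2)[nH]c1=O`) is unmeasured: methoxy in place of hydrogen on an aromatic carbon gives its difference from compound 3, methoxy in place of hydrogen on an aromatic carbon, para to a large group. Within the data shown here, no measured pair isolates this change. Compounds 1 and 2 both carry the 4-methoxyphenyl, yet neither gives a number. Compound 3 at 56000 nM is the sole anchor for the expectation. The expected step in this assay is none beyond the scatter, with a 1.1-fold lower number from compound 3 to compound 4 (0.05 log units; within the scatter) as the estimated move. Compound 4 is estimated at 50000 nM with an expected range of 20000 nM to 110000 nM for the measurement.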

Compound 4, half-maximal cytotoxic concentration: > 58000 nM
Compound 4: only a limit was reported; the forecaster's own chance of this, stated with the estimate: 50%; middle value at least 1.1-fold (0.06 log units) away from the limit.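

In this assay, the change from phenyl to 4-methoxyphenyl, para to a large group, now has its first measured pair: an at least 1.0-fold higher number from compound 3 to compound 4 (0.01 log units; that floor lies within the scatter). Compound 4 gives > 58000 nM, which is a limit and not a number, so methoxy at this place shows no lowering of the number, while any rise remains unsized. The steps to compound 4 from compound 1 and compound 2 cannot be read.

From the compounds shown here alone, how far the true value of compound 4 lies past its limit stays open. Also open, going by these compounds, is how an amine or a carboxylic acid at this place would read in this assay.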